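Ester variation on a furan-bearing core at adenosine A2b

The source may report more compounds than this note shows. Statements on the series, on what has been measured and on what is new or still open speak of the compounds shown alone.

The three measured compounds share one core and differ only in the ester group. Compound 1 `CC1=C(C(=O)OC(C)(C)C)C(c2ccoc2)NC(=O)N1` gives 4440 nM in an assay on membranes from HEK293 cells for displacement of a labelled ligand from adenosine receptor A2b (Homo sapiens), read by scintillation counting, with a stated time of 30 min (on this read-out higher numbers stand for weaker inhibition and lower numbers for stronger inhibition), and compound 2 `CC1=C(C(=O)OCc2ccccc2)C(c2ccoc2)NC(=O)N1` gives 6650 nM in this assay; the step of a 1.5-fold higher number from compound 1 to compound 2 (0.18 log units; within the scatter) is small. Compound 3 `CCC(C)OC(=O)C1=C(C)NC(=O)NC1c1ccoc1` gives 201 nM in this assay and stands lowest of the three, with the step of a 22-fold lower number from compound 1 to compound 3 (1.34 log units; beyond the scatter) and the step of a 33-fold lower number from compound 2 to compound 3 (1.52 log units; beyond the scatter) both large, so compound 3 is the strongest inhibitor here.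

Compound 4 `CC1=C(C(=O)OCC2CCC2)C(c2ccoc2)NC(=O)N1` differs from compound 3 by the change (cyclobutylmethyl in place of sec-butyl on an oxygen next to a carbonyl group). Within the data shown here, no measured step swaps one alkyl ester group for another such group; the two large steps show that a sec-butyl ester stands well apart from tert-butyl and benzyl, but they do not say how cyclobutylmethyl compares. The estimate for compound 4 therefore rests on compound 3 alone, with a step of a 1.7-fold higher number from compound 3 to compound 4 (0.24 log units; within the scatter) expected to stay near the scatter, leaning toward a slightly higher number. Compound 4 is expected to give 350 nM in this assay, within a range of 120 nM to 1100 nM.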

Compound 4, inhibition constant: 739 nM
Beside the measured number, compound 4's estimate is 2.1-fold (0.32 log units) below it, and the stated range covers the measured number.
By their numbers in this assay, from the lowest: compound 3; then compound 4; then compounds 1 and 2 (each within the scatter of the next).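

Among these compounds, replacing sec-butyl with cyclobutylmethyl on an oxygen next to a carbonyl group adds a four-membered ring and moves the number beyond the scatter in this assay (a 3.7-fold higher number from compound 3 to compound 4 (0.57 log units; beyond the scatter)), so this position distinguishes between two alkyl groups, which the earlier steps could not show. The cyclobutylmethyl ester also stands clear of the tert-butyl and benzyl esters (a 6.0-fold lower number from compound 1 to compound 4 (0.78 log units; beyond the scatter); a 9.0-fold lower number from compound 2 to compound 4 (0.95 log units; beyond the scatter)), so among these four compounds sec-butyl is not the only group that separates from those two. Nothing available explains these differences.

The compounds shown leave open how an unbranched n-butyl chain or a cyclopropylmethyl group would compare at this position. They also leave open how an amide in place of the ester would read.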